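Shortening the ester chain of a cytosine nucleoside ester

The source may hold more compounds than are shown below. What is called first, only, known or untested is meant among the compounds shown, and "the series" means these compounds.

Measured compounds:
compound 1, `CCCCCCCC/C=C/CCCCCCCC(=O)O[C@H]1[C@H](O)[C@H](n2ccc(N)nc2=O)O[C@@H]1CO`, 0.05 ug/mL
compound 2, `CCCCCCCCCCCCCCCCCCCCCC(=O)OC[C@H]1O[C@@H](n2ccc(N)nc2=O)[C@@H](O)[C@@H]1OC(=O)CCCCCCCCCCCCCCCCCCCCC`, > 10 ug/mL

Within the data shown here, compound 1 has the only numerical value shown in a functional assay on HeLa cells (Homo sapiens) for cytotoxicity, read by cell counting, with a stated time of 48 h (a higher number here means that more compound is needed for the effect, a lower number that less compound is needed), where compound 1 gives 0.05 ug/mL. Compound 2 stands at a limit of this assay: in this assay compound 2 gives > 10 ug/mL, a limit and not a number, as the limit of > 10 ug/mL in this assay, at which 1 of the 2 values shown sits, records. The unmeasured compound 3, `C=CCCCCCCCCC(=O)O[C@H]1[C@H](O)[C@H](n2ccc(N)nc2=O)O[C@@H]1CO`, differs from compound 1 by a group of 3 heavy atoms (3 carbon; no ring) in place of a group of 10 heavy atoms (10 carbon; no ring), on a saturated chain carbon, seven bonds along the chain from a carbonyl carbon. The acyl chain is thus much shorter than in compound 1 while keeping a single ester on the shared core. Among the measured compounds shown here, with no step between measured compounds available, the direction of change rests on expectation alone: the shorter chain is expected to cost some activity, with a step from compound 1 to compound 3 of a 6.0-fold higher number from compound 1 to compound 3 (0.78 log units; beyond the scatter), beyond the usual scatter. Compound 3 is therefore estimated at 0.3 ug/mL, with a range from 0.05 ug/mL to 2 ug/mL in this assay.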

Compound 3, concentration for half-maximal effect: 0.05 ug/mL
Beside the measured number, compound 3's estimate is 6.0-fold (0.78 log units) above it; the range from low to high includes it.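

At this position, on a saturated chain carbon, seven bonds along the chain from a carbonyl carbon, allyl can take the place of the group of 10 heavy atoms in this assay, with no change at the digits printed from compound 1 to compound 3 (within the scatter), and the single ester on the shared core is kept. The full length of the chain in compound 1 is therefore not required for the effect in this assay, which compound 1 on its own could not show. Nothing measured here accounts for the shorter chain serving as well as the longer one.

From the compounds shown here alone, whether a still shorter chain, or an amine or a carboxylic acid at the chain end, would give the same value as compound 3 remains open. Among these compounds, compound 2 differs from compound 1 and compound 3 in more than one place, so no step to it can be read. Compound 2 gives > 10 ug/mL, which is a limit and not a number.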